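Notes on compound 4 against three measured analogues

The source may report more compounds than this note shows. Statements on the series, on what has been measured and on what is new or still open speak of the compounds shown alone.

Three compounds of the shared core have numbers in a functional assay on the whole organism (strain albino) for inhibition, with Rattus norvegicus as the target, read by paw edema, with a stated time of 1 h, at a dose of 20 mmol/kg by the intraperitoneal route; a higher number here means more inhibition at the dose given (going by the name of the read-out), a lower number less inhibition. Compound 1 `N#CC1=C(NCC(=O)N2CCOCC2)N(c2ccccc2)C(=O)N2CCCCC(N3CCCC3)C12` gives 43.9%. Compound 2 `N#CC1=C(NCC(=O)N2CCCC2)N(c2ccccc2)C(=O)N2CCCCC(N3CCCC3)C12` gives 40.1%. Compound 3 `N#CC1=C(/N=C/c2ccccc2)N(c2ccccc2)C(=O)N2CCCCC(N3CCCC3)C12` gives 46.5%, the highest of the three numbers, yet every gap to it is within the scatter: a number 2.6 percentage points higher from compound 1 to compound 3 (within the scatter) and a number 6.4 percentage points higher from compound 2 to compound 3 (within the scatter). The remaining pair is likewise close, a number 3.8 percentage points lower from compound 1 to compound 2 (within the scatter).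

Compound 4 `COC(=O)C(=O)NC1=C(C#N)C2C(N3CCCC3)CCCCN2C(=O)N1c1ccccc1` has not yet been measured in this assay. Against compound 3 the change is a group of 7 heavy atoms (3 carbon, 1 nitrogen, 3 oxygen; no ring) in place of a group of 8 heavy atoms (7 carbon, 1 nitrogen; one six-membered aromatic ring of carbon only), on a double-bonded ring carbon.

The two steps that bear on this position are those from compound 1 and from compound 2 into compound 3, where a ring-bearing amide side chain gave way to the group containing the six-membered aromatic ring and the number barely moved. The change to compound 4 reverses that kind of exchange, putting a chain without a ring back on the same ring carbon. On these three data points, substitution at this carbon has not produced a step beyond the scatter, so none is expected here either, and the estimated step is a number 4.5 percentage points lower from compound 3 to compound 4 (within the scatter).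

Compound 4 is therefore expected to give about 42% in this assay, within a range from 30% to 55%.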

Compound 4, a percentage reported as inhibition, in the whole organism at one dose (the size of the read-out at that dose, not a potency): 69.2%
Compound 4: the middle estimate sits 27.2 percentage points below what was measured; the whole stated range lies below it.
By their numbers in this assay, from the lowest: compounds 2, 1 and 3 (each within the scatter of the next); then compound 4.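

In this assay this position proves able to move the number beyond the scatter: the ((methoxycarbonyl)carbonyl)amino group gives a number 22.7 percentage points higher from compound 3 to compound 4 (beyond the scatter) when it replaces the group with the six-membered aromatic ring. On the amine nitrogen, (methoxycarbonyl)carbonyl likewise gives a number 29.1 percentage points higher from compound 2 to compound 4 (beyond the scatter) in place of ((pyrrolidin-1-yl)carbonyl)methyl and a number 25.3 percentage points higher from compound 1 to compound 4 (beyond the scatter) in place of ((morpholin-4-yl)carbonyl)methyl, so an amine nitrogen on this ring carbon does not by itself go with the higher number, since compound 1 and compound 2 carry one too. No measurement shown explains the gain, and the reason for it remains unknown.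

Among these compounds, compound 4 is the only compound here with a ring-free group at this carbon, so the result cannot be assigned to the loss of a ring or to the methyl ester in particular. A carboxylic acid or an ethyl ester in place of the methyl ester, or a plain acetyl group on the same amine nitrogen, would show which part of the group travels with the number, and the single dose gives the size of the read-out but no potency.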